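From 2-chlorophenyl to 2-nitrophenyl: a step toward compound 4

This account rests on a few compounds, and the source may have more. Where it says the series, first, only, none or still open, it means among the compounds named here.

In an ADME assay on MT4 cells (Homo sapiens) for cytotoxicity, read by MTT assay (a lower number here means that less compound is tolerated, a higher number that more compound is tolerated), compound 1 `Cc1cnc(NC(=O)CSc2nncnc2-c2ccccc2Cl)c(Br)c1` gives 144000 nM while compound 2 `O=C(CSc1nncnc1-c1ccccc1Cl)Nc1ccc(Cl)cc1Cl` gives 51000 nM and compound 3 `O=C(CSc1nncnc1-c1ccccc1Cl)Nc1ccccc1Cl` gives 90000 nM as its reading. Compound 3 sits in the middle of these three numbers, yet the data cannot separate it from either neighbour: the gaps are a 1.6-fold lower number from compound 1 to compound 3 (0.20 log units; within the scatter) and a 1.8-fold higher number from compound 2 to compound 3 (0.25 log units; within the scatter) and both stay within the usual scatter.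

Compound 4 `O=C(CSc1nncnc1-c1ccccc1Cl)Nc1ccccc1[N+](=O)[O-]` alters one group of compound 3 as follows: nitro in place of chloro on an aromatic carbon with nitro in place of chloro on an aromatic carbon, ortho to a large group. Among the measured compounds shown here, no measured step makes this exact swap, and no compound measured so far carries a nitro group. The nearest guide is how little the number has moved when the group on the amide-type nitrogen changed. The largest such step is a 2.8-fold lower number from compound 1 to compound 2 (0.45 log units; beyond the scatter) and it remains modest. A clear jump is therefore not expected, though the uncertainty stays wide. The expected step is a 1.3-fold lower number from compound 3 to compound 4 (0.11 log units; within the scatter) and that is no more than an estimate. In this assay compound 4 is estimated at 70000 nM with an expected range of 28000 nM to 150000 nM around that figure.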

Compound 4, half-maximal cytotoxic concentration: 63000 nM
The estimate for compound 4 lay 1.1-fold (0.05 log units) above the measured number, within the range that was stated.
By their numbers in this assay, from the lowest: compounds 2, 4, 3 and 1 (each within the scatter of the next, the first and the last beyond it).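

In this assay, nitro on an aromatic carbon, ortho to a large group, brings three heavy atoms and two hydrogen-bond acceptors where chloro had one heavy atom and none, yet the result is a 1.4-fold lower number from compound 3 to compound 4 (0.15 log units; within the scatter) and this larger group therefore leaves no readable mark on the number at this place. Compound 4 also cannot be told apart from the dichlorinated compound, with a 1.2-fold higher number from compound 2 to compound 4 (0.09 log units; within the scatter) as the printed step, while a 2.3-fold lower number from compound 1 to compound 4 (0.36 log units; beyond the scatter) shows a modest gap that does exceed the scatter, so compound 4 joins compound 2 in standing clearly apart from compound 1, which compound 3 does not do. No measurement here explains why these numbers fall where they do.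

The compounds shown leave open whether an amine or a carboxylic acid on this same aromatic carbon would also leave the number within the scatter of compound 3. They also leave open whether nitro would give a similar result in place of the bromo group on the 3-bromo-5-methylpyridin-2-yl ring of compound 1.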